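From 4-methylphenyl to phenyl: a small step expected

The source may report more compounds than this note shows. Statements on the series, on what has been measured and on what is new or still open speak of the compounds shown alone.

Two compounds have so far been measured in a functional assay on HCT-116 cells (Homo sapiens) for antiproliferative activity, read by CCK-8 assay, with a stated time of 72 h (a higher number here means a weaker inhibitor, a lower number a stronger inhibitor), with these results:

Compound 1 (`CCC(C)n1cnc2c(NCc3ccc(C(=O)Nc4ccccc4N)cc3)nc(Cl)nc21`) gives 720 nM
Compound 2 (`Cc1ccc(Nc2nc(Cl)nc3c2ncn3Cc2ccc(C(=O)Nc3ccccc3N)cc2)cc1`) gives 580 nM

These two values lie within the usual scatter of each other, so compound 2 stands level with compound 1 and neither can be ranked over the other. Among the compounds with values here, the two compounds differ in more than one place, and no single-change step between measured compounds is available.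

Compound 3 (`Nc1ccccc1NC(=O)c1ccc(Cn2cnc3c(Nc4ccccc4)nc(Cl)nc32)cc1`) has not yet been measured. It differs from compound 2 in one place, with hydrogen in place of methyl on an aromatic carbon turning 4-methylphenyl into phenyl.

Within the data shown here, with compound 1 at 720 nM and compound 2 at 580 nM as the only guides, no change beyond the scatter is expected in this assay in either direction. The expected result is a 1.1-fold higher number from compound 2 to compound 3 (0.03 log units; within the scatter) by this estimate. For compound 3 the estimated value is 620 nM with an expected range from 270 nM to 1400 nM in a repeated measurement.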

Compound 3, half-maximal inhibitory concentration: 1070 nM
Compound 3: middle estimate off by 1.7-fold (0.24 log units), on the low side; the range from low to high includes it.
By their numbers in this assay, from the lowest: compounds 2, 1 and 3 (each within the scatter of the next).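

Within the data shown here, the replacement of methyl by hydrogen on an aromatic carbon, para to a large group, turns 4-methylphenyl into phenyl and gives the first single-change step in this set: in this assay it reads a 1.8-fold higher number from compound 2 to compound 3 (0.27 log units; within the scatter) and so offers a direct view of this position, which compound 1 and compound 2 could not give. On this one pair, the methyl cannot be said to matter for the read-out, since compound 2 and compound 3 stand level and the methyl's contribution, if it has one, cannot be separated from the scatter. Nothing at hand bears on the reason for this result.

On these data alone, it remains open whether a different group on the same aromatic carbon, such as methoxy, chlorine, an amine or a carboxylic acid, would give a step beyond the scatter, since methyl and hydrogen are the only two seen there. As far as these compounds go, it is also open whether the same replacement would read alike on another version of the shared core, as compound 1 differs from the other two in more than one place and offers no such comparison.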